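Nitroanilino series: dichlorophenyl swap from compound 1

The compounds below may be only part of what the source reports. "The series", "measured", "known", "first", "only" and "open" are said of these compounds alone.

Two compounds of the shared core have numbers in a functional assay on A549 cells (Homo sapiens) for antiproliferative activity, read by MTT assay; on this read-out higher numbers stand for weaker inhibition and lower numbers for stronger inhibition. Compound 1 `O=[N+]([O-])c1ccc(Nc2nccc(-c3ccc(F)cc3)n2)cc1` gives 84000 nM and stands highest of the two, the weaker inhibitor. Compound 2 `Clc1ccc(Nc2nccc(-c3ccc(Cl)cc3Cl)n2)c(Cl)c1` gives 11600 nM, a lower number beyond the scatter; compound 2 differs from compound 1 in both aryl groups, so its gap cannot be split between them.

Compound 3 `O=[N+]([O-])c1ccc(Nc2nccc(-c3ccc(Cl)cc3Cl)n2)cc1` keeps the nitrophenyl of compound 1 and carries the change (2,4-dichlorophenyl in place of 4-fluorophenyl on an aromatic carbon).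

Within the data shown here, no single-point step between measured compounds is available to size this change. A step toward stronger inhibition is expected from compound 1 to compound 3, of moderate size and likely beyond the scatter, because compound 2 gives 11600 nM while carrying the same 2,4-dichlorophenyl. The expected step is a 3.0-fold lower number from compound 1 to compound 3 (0.48 log units; beyond the scatter). For compound 3 the estimated value in this assay is 28000 nM, within a range from 9000 nM to 80000 nM.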

Compound 3, half-maximal inhibitory concentration: 119000 nM
Compound 3: the middle estimate sits 4.3-fold (0.63 log units) below what was measured; the measured number lies above the stated range.
By their numbers in this assay, from the lowest: compound 2; then compounds 1 and 3 (each within the scatter of the next).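

In this assay, a 1.4-fold higher number from compound 1 to compound 3 (0.15 log units; within the scatter), so with the nitrophenyl kept, 2,4-dichlorophenyl and 4-fluorophenyl are not told apart at this position on the shared core. Compound 3 gives 119000 nM, while compound 2, which carries the same 2,4-dichlorophenyl but a different second aryl group, gives 11600 nM; the lower number of compound 2 therefore does not follow from 2,4-dichlorophenyl alone. No measurement is at hand that offers an explanation for this result.

Still open, going by these compounds, is whether the swap reads the same when the second aryl group of compound 2 replaces the nitrophenyl. Also open, on these data alone, is how an amine or a carboxylic acid at this position would compare with either aryl group.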